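Trimming an Ethyl Chain in a Weakly Active Pair

The source may report more compounds than this note shows. Statements on the series, on what has been measured and on what is new or still open speak of the compounds shown alone.

Compound 2 `C=C1C(=O)N(c2ccccc2)N(C)C1CC` gives the highest of the two numbers recorded so far in a functional assay on HL-60 cells (Homo sapiens) for inhibition, read by MTT assay, with a stated time of 48 h (on this read-out higher numbers stand for weaker inhibition and lower numbers for stronger inhibition), reading 750000 nM. Compound 1 `C=C1C(=O)N(c2ccccc2)N(c2ccccc2)C1C` is the nearest neighbour of compound 2 in this assay; in this assay compound 1 gives 5850 nM, a far lower number that lies well beyond the scatter. Compound 3 `C=C1C(=O)N(c2ccccc2)N(C)C1C` differs from compound 2 in one place: hydrogen in place of methyl on a saturated chain carbon bound to a saturated ring carbon, which read one bond further out is ethyl to methyl. Among the measured compounds shown here, no measured pair isolates this change, so its size is unknown. The step of a 2.5-fold lower number from compound 2 to compound 3 (0.40 log units; beyond the scatter) is expected to be modest, toward a lower number. Compound 3 is estimated at 300000 nM, within a range of 60000 nM to 1500000 nM.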

Compound 3, half-maximal inhibitory concentration: 531000 nM
For compound 3 the middle estimate is 1.8-fold (0.25 log units) below the measured one, and the stated range covers the measured number.
By their numbers in this assay, from the lowest: compound 1; then compounds 3 and 2 (each within the scatter of the next).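

In this assay, cutting ethyl to methyl on a saturated chain carbon bound to a saturated ring carbon gives a 1.4-fold lower number from compound 2 to compound 3 (0.15 log units; within the scatter) and stays within the scatter, so this change does not separate the two compounds. Methyl in place of phenyl on an amine nitrogen in a ring gives a 91-fold higher number from compound 1 to compound 3 (1.96 log units; beyond the scatter) and lies far beyond the scatter, so the large gap goes with that ring nitrogen substituent rather than with the chain. No available evidence bears on either step.

Still open, as far as these compounds go, is how a longer chain would read at the chain position. Also open, from the compounds shown here alone, is how a benzyl group would read on the ring nitrogen.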